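This account rests on a few compounds, and the source may have more. Where it says the series, first, only, none or still open, it means among the compounds named here.

Compounds measured in a functional assay on the whole organism (Tail, strain ICR) with Mus musculus as the target, in the tail flick test, with a stated time of 90 min, at a dose of 25 umol/kg by the oral route; a lower number here means a weaker effect, a higher number a stronger effect of the compound at the dose given:
compound 1 `O=C(O)[C@@H]1CCCN1C(=O)CN(c1nc(Cl)nc2[nH]cnc12)C1CC1` with 26%
compound 2 `CSCC[C@H](NC(=O)CN(c1nc(Cl)nc2[nH]cnc12)C1CC1)C(=O)OCc1ccccc1` with 44.6%
compound 3 `O=C(CN(c1nc(Cl)nc2[nH]cnc12)C1CC1)N[C@@H](CC(=O)OCc1ccccc1)C(=O)OCc1ccccc1` with 15.6%

Compound 1 stands second highest of the three numbers in this assay: compound 3 sits closest to it and lower, beyond the scatter, while compound 2 sits furthest from it and higher, again beyond the scatter. Among the measured compounds shown here, the only step between two measured compounds that differ in one place is a number 29 percentage points lower from compound 2 to compound 3 (beyond the scatter), where benzyloxycarbonyl replaced (methylsulfanyl)methyl on a saturated chain carbon.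

Compound 4 `O=C(OCc1ccccc1)[C@@H]1CCCN1C(=O)CN(c1nc(Cl)nc2[nH]cnc12)C1CC1` is not yet measured. Relative to compound 1 it shows (benzyl in place of hydrogen on an oxygen next to a carbonyl group). For the measured compounds named here, no measured pair isolates this change: compounds 2 and 3 both already carry a benzyl ester and differ from each other elsewhere, and the step from compound 2 to compound 3 does not bear directly on it. The two benzyl esters give the highest and the lowest numbers, so they set no clear direction. Compound 4 is therefore expected to lie in a wide band, with a number 7 percentage points higher from compound 1 to compound 4 (within the scatter) and an estimate of 33% ranging from 14% to 52%.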

Compound 4, a percentage reported as activity, at one dose (the size of the read-out at that dose, not a potency): 43.3%
Beside the measured number, compound 4's estimate is 10.3 percentage points below it; the range from low to high includes it.
By their numbers in this assay, from the lowest: compound 3; then compound 1; then compounds 4 and 2 (each within the scatter of the next).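

In this assay, among the compounds shown here, the step of a number 17.3 percentage points higher from compound 1 to compound 4 (beyond the scatter) is the first measured change at the carboxy group itself, since the earlier step altered only a side chain and left the benzyl ester in place. It shows that at this position, on an oxygen next to a carbonyl group, benzyl in place of hydrogen is not a neutral change, and that the carboxy compound and its benzyloxycarbonyl counterpart can be told apart at the single dose given. Nothing shown here gives a reason for this step.

The compounds shown leave open whether a smaller methyl ester or a primary amide at this carbonyl would give a similar number. They also leave open whether the same change would hold on the side chains of compound 2 and compound 3, whose free carboxylic acid forms are not among those shown.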